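Swapping the aryl group on the shared core of compound 1

The source may hold more compounds than are shown below. What is called first, only, known or untested is meant among the compounds shown, and "the series" means these compounds.

Measured so far:
Compound 1 `CC/C(=C(/c1ccc(/C=C/C(=O)O)cc1)c1cc2ccccc2[nH]1)c1cccc(C(F)(F)F)c1`: 325 nM
Compound 2 `CC/C(=C(/c1ccc(/C=C/C(=O)O)cc1)c1cc2ccccc2[nH]1)c1ccc(C#N)cc1`: 278 nM
Compound 3 `CC/C(=C(/c1ccc(/C=C/C(=O)O)cc1)c1cc2ccccc2[nH]1)c1ccc(OC)cc1`: 61 nM

Of the compounds shown here, three sharing one core have been tested in a functional assay on MCF7 cells (Homo sapiens) for inhibition; a higher number here means a weaker inhibitor, a lower number a stronger inhibitor. Compound 1 gives the highest number of the three. Its nearest neighbour is compound 2, with a 1.2-fold lower number from compound 1 to compound 2 (0.07 log units; within the scatter), a difference too small to read as real. Compound 3 sits furthest away, with a 5.3-fold lower number from compound 1 to compound 3 (0.73 log units; beyond the scatter), a modest but genuine gain; the same gain appears as a 4.6-fold lower number from compound 2 to compound 3 (0.66 log units; beyond the scatter).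

Compound 4 `CC/C(=C(/c1ccc(/C=C/C(=O)O)cc1)c1cc2ccccc2[nH]1)c1ccc(F)cc1Cl` is the next step from compound 1: 2-chloro-4-fluorophenyl in place of 3-(trifluoromethyl)phenyl on a double-bonded chain carbon bound to a double-bonded chain carbon and a saturated chain carbon. Within the data shown here, no measured step makes exactly this exchange, so the two steps out of compound 1 frame what can be expected. One aryl swap at this position left the number essentially unchanged, the other lowered it modestly. A change between those two outcomes is therefore expected in this assay, most likely a small drop in the number, with a genuine chance of none beyond the scatter.

For compound 4 the expected value is 200 nM, within a range of 70 nM to 600 nM, which corresponds to an estimated step of a 1.6-fold lower number from compound 1 to compound 4 (0.21 log units; within the scatter).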

Compound 4, half-maximal inhibitory concentration: 39 nM
The estimate for compound 4 lay 5.1-fold (0.71 log units) above the measured number, outside the stated range (below it).
By their numbers in this assay, from the lowest: compounds 4 and 3 (each within the scatter of the next); then compounds 2 and 1 (each within the scatter of the next).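

In this assay, the 2-chloro-4-fluorophenyl group gives an 8.3-fold lower number from compound 1 to compound 4 (0.92 log units; beyond the scatter) and a 7.1-fold lower number from compound 2 to compound 4 (0.85 log units; beyond the scatter), so a group carrying two halogen atoms on its ring can also produce a clear shift at this place on the double-bonded chain carbon. Among these compounds, the comparison with the 4-methoxyphenyl compound gives a 1.6-fold lower number from compound 3 to compound 4 (0.19 log units; within the scatter), which means these two compounds cannot be told apart and the 4-methoxyphenyl group is not the only aryl group that reaches this level. The four compounds therefore fall into two pairs, with compounds 3 and 4 on the lower side and compounds 1 and 2 on the higher, and no evidence is available to explain that split.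

Since the chlorine and the fluorine enter together, the result does not assign the shift to either atom; a 2-chlorophenyl or a 4-fluorophenyl group would be needed to separate them. On these data alone, it also remains open how a plain phenyl group, or an aryl group bearing an amine, would behave at this place on the shared core.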